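The source may report more compounds than this note shows. Statements on the series, on what has been measured and on what is new or still open speak of the compounds shown alone.

Compound 1 `Ic1ccc2[nH]cc(Cc3c[nH]c4ccc(I)cc34)c2c1` in an ADME assay on WS1 cells (Homo sapiens) for cytotoxicity, read by MTT assay, with a stated time of 48 h (a higher number here means a weaker inhibitor, a lower number a stronger inhibitor), gives 13000000 nM.
Compound 2 `Cc1ccc(C(c2c[nH]c3ccc(I)cc23)c2c[nH]c3ccc(I)cc23)cc1` in this assay gives 16200000 nM.

The two compounds share a core, whose structure stands beside each of them. For the measured compounds named here, the only step yet measured is a 1.2-fold higher number from compound 1 to compound 2 (0.10 log units; within the scatter), so the two numbers cannot be told apart. Compound 2 holds the higher of the two numbers, but its nearest neighbour, compound 1, stands within the scatter of it, so no order between them can be claimed.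

Compound 3 `Fc1cc(F)cc(C(c2c[nH]c3ccc(I)cc23)c2c[nH]c3ccc(I)cc23)c1` is the next compound. It differs from compound 2 in one place: 3,5-difluorophenyl in place of 4-methylphenyl on a saturated chain carbon bound to two aromatic carbons. The step from compound 1 to compound 2 bears on this only loosely, since it changed what sits on that same chain carbon and left the number where it was. Going by the values given here, no measured step tells what a swap of one aryl group for another at that carbon does here. On this basis compound 3 is expected to give a 1.1-fold lower number from compound 2 to compound 3 (0.03 log units; within the scatter), a step of no size beyond the scatter in this assay. The estimate for compound 3 is 15000000 nM, with a range from 6000000 nM to 40000000 nM.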

Compound 3, half-maximal inhibitory concentration: 28500000 nM
Compound 3: middle estimate off by 1.9-fold (0.28 log units), on the low side, within the range that was stated.
By their numbers in this assay, from the lowest: compounds 1, 2 and 3 (each within the scatter of the next, the first and the last beyond it).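

For the compounds shown here, at the saturated chain carbon bound to two aromatic carbons, this is the first exchange of one aryl group for another, and in this assay it gives a 1.8-fold higher number from compound 2 to compound 3 (0.25 log units; within the scatter), so 3,5-difluorophenyl and 4-methylphenyl cannot be told apart at this position. The comparison with hydrogen on the same carbon does give a first separation, though only a modest one: a 2.2-fold higher number from compound 1 to compound 3 (0.34 log units; beyond the scatter), whereas the 4-methylphenyl exchange stayed inside the scatter with a 1.2-fold higher number from compound 1 to compound 2 (0.10 log units; within the scatter), and this single step beyond the scatter is too little to support a trend across the three compounds. No measurement is at hand that would account for this result.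

The compounds shown leave open whether the separation from hydrogen belongs to the fluorine atoms or to the aryl ring itself, a question that a plain phenyl at the same carbon would address. They also leave open how this position responds to groups of another kind, such as an amine, a carboxylic acid or a longer chain, in place of the aryl ring.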